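Hydroxy in Place of Methoxy on the Pyrazole Aryl Arm

A few compounds are considered here, and "the series" means these few. Any claim that something is new, unique, unknown or untested is made for them only; others in the source may bear on it.

Measured so far:
compound 1 `O=C(Nc1cccc(-n2cc(-c3ccncc3)c(-c3ccc(Cl)c(O)c3)n2)c1)Nc1cccc(C(F)(F)F)c1` — 13700 nM
compound 2 `COc1cc(-c2nn(-c3cccc(NC(=O)Nc4ccc(Cl)c(Cl)c4)c3)cc2-c2ccncc2)ccc1Cl` — 2130 nM

In a functional assay on OVCAR-5 cells (Homo sapiens) for inhibition, read by sulforhodamine B assay, with a stated time of 48 h (on this read-out higher numbers stand for weaker inhibition of growth and lower numbers for stronger inhibition of growth), compound 2 gives the lower of the two numbers; compound 1 sits well beyond the scatter above it. Compound 3 `O=C(Nc1cccc(-n2cc(-c3ccncc3)c(-c3ccc(Cl)c(O)c3)n2)c1)Nc1ccc(Cl)c(Cl)c1` is not yet measured. It differs from compound 2 by hydrogen in place of methyl on an oxygen on an aromatic ring. Among the measured compounds shown here, no single-change step of this kind stands among the measured pair, so no measured size can be quoted for it; the expected step from compound 2 to compound 3 is a 1.9-fold higher number from compound 2 to compound 3 (0.27 log units; within the scatter), a modest weakening that may not exceed the scatter. Compound 3 is expected to give 4000 nM, within 1500 nM to 12000 nM.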

Compound 3, concentration for 50% growth inhibition: 2400 nM
For compound 3 the middle estimate is 1.7-fold (0.22 log units) above the measured one, and the stated range covers the measured number.
By their numbers in this assay, from the lowest: compounds 2 and 3 (each within the scatter of the next); then compound 1.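

In this assay, methoxy to hydroxy on an oxygen on an aromatic ring gives a 1.1-fold higher number from compound 2 to compound 3 (0.05 log units; within the scatter), so the two groups cannot be told apart at this position with the 3,4-dichlorophenyl group in place. Among the compounds shown here, with the hydroxy held, 3,4-dichlorophenyl in place of 3-(trifluoromethyl)phenyl on an amide-type nitrogen gives a 5.7-fold lower number from compound 1 to compound 3 (0.76 log units; beyond the scatter), and only this step lies beyond the scatter. Nothing available gives a cause for either result. Open, going by these compounds, is how an amine or an ethoxy group would read at this position, and whether methoxy to hydroxy reads the same alongside 3-(trifluoromethyl)phenyl.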